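Adding One Methoxy Group to Compound 3

The source may report more compounds than this note shows. Statements on the series, on what has been measured and on what is new or still open speak of the compounds shown alone.

Three compounds have a reading so far in a functional assay on TK-10 cells (Homo sapiens) for inhibition, read by sulforhodamine B assay, with a stated time of 48 h, tested at 10 uM (on this read-out higher numbers stand for more inhibition of growth at the one concentration tested and lower numbers for less inhibition of growth), and each was tested at a single concentration. Compound 1 `C/C(=N/O)c1ccc(NC(=O)Cn2nc(C(F)(F)F)nc2N)cc1` gives 14.3% and compound 2 `COc1cc(-c2nc(N)n(CC(=O)Nc3ccc(/C(C)=N\O)cc3)n2)cc(OC)c1OC` gives 9.11% while compound 3 `Clc1ccc(-c2cn3nc(-c4ccccc4)nc3s2)cc1` gives 18% on the same scale. Compound 3 therefore stands level with the other two, since all three numbers lie within the usual scatter of one another and cannot be ranked.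

The next compound to be tested is compound 4 `COc1ccc(-c2nc3sc(-c4ccc(Cl)cc4)cn3n2)cc1`, which keeps the core of compound 3 and differs from it in one place. It carries methoxy in place of hydrogen on an aromatic carbon, para to a large group (methoxy in place of hydrogen on an aromatic carbon).

For the measured compounds named here, no pair of tested compounds differing in one place is available, so nothing yet shows how large a single change can be in this assay. The best guide is compound 3 with its 18% reading, as it is the closest relative of compound 4. No shift beyond the scatter is expected, and the estimated step of a number 1 percentage points higher from compound 3 to compound 4 (within the scatter) has no firm direction behind it. The expected reading for compound 4 is 19% within an estimated range from 6% to 35% for a single measurement.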

Compound 4, percent growth inhibition at one concentration: -30.8%
Compound 4: the middle estimate sits 49.8 percentage points above what was measured; measured number below the stated range.
By their numbers in this assay, from the lowest: compound 4; then compounds 2, 1 and 3 (each within the scatter of the next).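

In this assay, for the compounds shown here, the first step between two compounds that differ in one place is a number 48.8 percentage points lower from compound 3 to compound 4 (beyond the scatter) and it shows that methoxy in place of hydrogen on an aromatic carbon, para to a large group, can move the reading far beyond the usual scatter. The earlier compounds shown here could not show this, as their numbers all lie within the scatter of one another and no pair among them differs in one place, so they gave no sign that a single small change could matter so much here. Nothing available explains why this one change has so large an effect, and no measured property of the compounds bears on it.

From the compounds shown here alone, it remains open whether a hydroxy group, a fluorine atom or an amine at this same place would shift the reading in the same direction and by a similar amount, or whether the effect is particular to methoxy. Going by these compounds, it is also open whether methoxy on another carbon of this ring, or a longer ether such as ethoxy, would behave as it does here.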